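The compounds below may be only part of what the source reports. "The series", "measured", "known", "first", "only" and "open" are said of these compounds alone.

Measured compounds:
compound 1, `Cc1ccc(-c2csc(NC(=O)COc3ccccc3)n2)cc1`, 50100 nM
compound 2, `Cc1ccc(-c2csc(NC(=O)COc3ccccc3C(C)C)n2)cc1`, 42900 nM
compound 3, `CC(C)c1ccccc1OCC(=O)Nc1nc(-c2ccc(Cl)cc2)cs1`, 50100 nM

All three values come from a functional assay on Ehrlich cells (Mus musculus) for cytotoxicity, read by MTT assay, with a stated time of 48 h (on this read-out higher numbers stand for weaker inhibition and lower numbers for stronger inhibition), and the three numbers sit close together: a 1.2-fold lower number from compound 1 to compound 2 (0.07 log units; within the scatter) and a 1.2-fold higher number from compound 2 to compound 3 (0.07 log units; within the scatter). Compound 3 stands level with compound 1 at the digits given, and both are within the scatter of compound 2, so no order among the three can be read from these values.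

The change from compound 1 to compound 2 is isopropyl in place of hydrogen on an aromatic carbon. The change from compound 3 to compound 4, `CC(C)c1ccc(OCC(=O)Nc2nc(-c3ccc(Cl)cc3)cs2)c(C(C)C)c1`, is isopropyl in place of hydrogen on an aromatic carbon. The two entering groups are the same, but the surroundings differ: in compound 2 the isopropyl sits ortho to a large group, while in compound 4 it sits meta to an isopropyl group and para to a large group, so this is the same kind of change rather than the same one. The difference between the cores of compound 1 and compound 3 is not broken down here.

Because the first such step, a 1.2-fold lower number from compound 1 to compound 2 (0.07 log units; within the scatter), stayed within the scatter, the step of a 1.1-fold lower number from compound 3 to compound 4 (0.05 log units; within the scatter) is expected to be small as well. Compound 4 is therefore estimated at 45000 nM, likely between 20000 nM and 100000 nM.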

Compound 4, half-maximal inhibitory concentration: 62200 nM
Compound 4: middle estimate off by 1.4-fold (0.14 log units), on the low side; the range from low to high includes it.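

In this assay, isopropyl in place of hydrogen gave a 1.2-fold higher number from compound 3 to compound 4 (0.09 log units; within the scatter), and this step and the earlier one on the other core cannot be told apart: the same change on two cores in this assay, a 1.2-fold lower number (0.07 log units; within the scatter) from compound 1 to compound 2 and a 1.2-fold higher number (0.09 log units; within the scatter) from compound 3 to compound 4, 1.4-fold (0.16 log units) apart, within the scatter of two such steps

So across these two cores, the change carries over in the sense that both steps stay small, within the scatter of repeated measurements. It does not show that the number falls on one core and rises on the other, since neither step can be told from scatter, and two pairs cannot establish a rule for other cores, especially as the entering isopropyl does not stand in the same place in the two pairs.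

On these data alone, what stays open is whether a different group at these places, such as an amine, a carboxylic acid or a longer chain, would move the number beyond the scatter. As far as these compounds go, whether the isopropyl step would also stay this small in other cells remains open too, as all the values shown come from this single assay.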